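Sulfonyl in Place of Phenyl on the Piperazine Nitrogen

The compounds below may be only part of what the source reports. "The series", "measured", "known", "first", "only" and "open" are said of these compounds alone.

Measured so far:
compound 1, `Cc1ccc(N2CCN(c3ccc(C(=O)/C=C/c4ccccc4)cc3)CC2)c(C)c1`, gives 15%
compound 2, `O=C(/C=C/c1ccccc1)c1ccc(N2CCN(c3ccccc3)CC2)cc1`, gives 3.71%

In a functional assay on the whole organism (strain Kunming) for inhibition, with Mus musculus as the target, with a stated time of 1 h, at a dose of 40 mg/kg by the oral route (on this read-out lower numbers stand for less inhibition and higher numbers for more inhibition at the one dose given (going by the name of the read-out)), compound 2 stands lowest of the two numbers, with compound 1 the nearest and higher. Among the compounds with values here, the only measured step is a number 11.3 percentage points lower from compound 1 to compound 2 (beyond the scatter), which swapped one aryl group for another at the same ring nitrogen.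

Compound 3, `O=C(/C=C/c1ccccc1)c1ccc(N2CCN(S(=O)(=O)c3ccc(Cl)cc3)CC2)cc1`, differs from compound 2 by (4-chlorophenyl)sulfonyl in place of phenyl on an amine nitrogen in a ring. Within the data shown here, no measured step covers this kind of change; the one known step bears on it only loosely, so little movement beyond the scatter is expected. Compound 3 is expected to give 10%, within 0% to 30%. The step this implies, a number 6.3 percentage points higher from compound 2 to compound 3 (within the scatter), is an estimate only.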

Compound 3, a percentage reported as inhibition, in the whole organism at one dose (the size of the read-out at that dose, not a potency): 46.8%
For compound 3 the middle estimate is 36.8 percentage points below the measured one; measured number outside the range, above it.
By their numbers in this assay, from the lowest: compound 2; then compound 1; then compound 3.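

In this assay, (4-chlorophenyl)sulfonyl in place of phenyl gives a number 43.1 percentage points higher from compound 2 to compound 3 (beyond the scatter) and in place of 2,4-dimethylphenyl gives a number 31.8 percentage points higher from compound 1 to compound 3 (beyond the scatter) on the same amine nitrogen in a ring. Both steps are large, while the exchange of one aryl group for another gives only the modest a number 11.3 percentage points lower from compound 1 to compound 2 (beyond the scatter), so this position responds far more to the sulfonyl change than to the aryl change. No measured evidence accounts for the rise.

The compounds shown do not separate the part played by the sulfonyl link from that of the 4-chlorophenyl ring. A methanesulfonyl or acetyl group on this nitrogen would bear on that question.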